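A few compounds are considered here, and "the series" means these few. Any claim that something is new, unique, unknown or untested is made for them only; others in the source may bear on it.

In a functional assay on the whole organism (strain Wistar Albino) for inhibition, with Rattus norvegicus as the target, read by paw edema, with a stated time of 2 h, at a dose of 20 mg/kg (a lower number here means less inhibition, a higher number more inhibition at the dose given (going by the name of the read-out)), compound 2 `COc1ccc(Cl)c(-c2nnc3sc(Cc4c(C)[nH]c5ccc(OC)cc45)nn23)c1` gives 20%. Compound 1 `COc1ccc2[nH]cc(Cc3nn4c(-c5ccoc5C)nnc4s3)c2c1` gives 20.1% in this assay, and the two numbers lie within the scatter of each other, so neither compound can be set above the other on this evidence. Compound 3 `COc1ccc2[nH]c(C)c(Cc3nn4c(-c5ccoc5C)nnc4s3)c2c1` has not yet been measured in this assay. It differs from compound 2 in one place: 2-methylfuran-3-yl in place of 2-chloro-5-methoxyphenyl on an aromatic carbon. Among the compounds with values here, no step between two measured compounds is known, so the size of this change cannot be read off a measured pair. Compound 1 already carries the 2-methylfuran-3-yl group, which makes a small effect plausible, because compound 1 with that group gives 20.1% in this assay. The expected step is no change at the digits printed from compound 2 to compound 3 (within the scatter), none beyond the scatter. Compound 3 is estimated at 20%, within a range from 10% to 32%.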

Compound 3, a percentage reported as inhibition, in the whole organism at one dose (the size of the read-out at that dose, not a potency): 24.8%
Compound 3: the middle estimate sits 4.8 percentage points below what was measured; the range from low to high includes it.
By their numbers in this assay, from the lowest: compounds 2, 1 and 3 (each within the scatter of the next).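

Within the data shown here, the step of a number 4.8 percentage points higher from compound 2 to compound 3 (within the scatter) in this assay is the first measured one at this carbon between two ring nitrogen atoms, and it shows that replacing 2-chloro-5-methoxyphenyl, with 9 heavy atoms, by 2-methylfuran-3-yl, with 6, stays within the scatter. The step of a number 4.7 percentage points higher from compound 1 to compound 3 (within the scatter) isolates methyl in place of hydrogen on an aromatic carbon of the shared core, and it also stays within the scatter, so neither change separates the compounds. Nothing shown gives a reason for this result.

On these data alone, it remains open whether an amine or a carboxylic acid in place of the aromatic ring at this carbon would shift this assay beyond the scatter. The same question stands for a longer chain in place of the methyl on the core.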